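Bromo to Methyl on a Weakly Active Benzamide

The compounds below may be only part of what the source reports. "The series", "measured", "known", "first", "only" and "open" are said of these compounds alone.

Compound 1 `Nc1ccccc1NC(=O)c1ccc(COc2ccc(Br)cc2)cc1` belongs to a small set of anilino-amides tested in a functional assay on HepG2 cells (Homo sapiens) for antiproliferative activity, read by CCK-8 assay, with a stated time of 72 h; on this read-out higher numbers stand for weaker inhibition and lower numbers for stronger inhibition. In this assay compound 1 gives > 32000 nM, which is a limit of the assay and not a measured number. Two further compounds share the same core. Compound 2 `Nc1ccccc1NC(=O)/C=C/c1ccc(CN2CCc3ccccc32)cc1` also gives only a limit in this assay, at > 32000 nM. Compound 3 `Nc1ccccc1NC(=O)c1ccc(CN2CCc3cc(Br)ccc32)cc1` gives a measured value in this assay of 10700 nM. Among the measured compounds shown here, compound 1 therefore stands at the limit of > 32000 nM in this assay, at which 2 of the 3 values shown sit, so its activity can only be said to lie beyond the reach of the assay, and nothing finer can be read from its value; compound 3 is the one member of the set that returned a number at all.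

Compound 4 `Cc1ccc(OCc2ccc(C(=O)Nc3ccccc3N)cc2)cc1` differs from compound 1 in one place: methyl in place of bromo on an aromatic carbon. For the measured compounds named here, no pair of measured compounds shows this change, so there is no measured step to lean on. With compound 1 already at a limit, a small exchange of one single-atom group for another is expected to move the read-out little, and the step from compound 1 to compound 4 is estimated as a step that the limit leaves unreadable from compound 1 to compound 4. Compound 4 is thus expected to give about 40000 nM in this assay, within a range of 15000 nM to 120000 nM, most likely reported again as a limit.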

Compound 4, half-maximal inhibitory concentration: 6590 nM
Compound 4: middle estimate off by 6.1-fold (0.78 log units), on the high side; measured number below the stated range.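

On the shared core, the place para to a large group turns out to matter: in this assay the change from 4-bromophenoxy to 4-methylphenoxy gives an at least 4.8-fold lower number from compound 1 to compound 4 (0.68 log units; beyond the scatter). From the compounds shown here alone, for compound 1 the figure > 32000 nM is a limit of the assay and not a number, so this step is a minimum and its full size stays unknown. This is the first pair in the set that differs in one place, and it shows that a swap of one heavy atom for another can bring a compound from a limit to a measured number, even though limits remain common in the set: the limit of > 32000 nM in this assay, at which 2 of the 4 values shown sit.

The compounds shown do not tell whether methyl is especially favourable here or whether bromo is simply unfavourable, and other groups at this place, such as methoxy, an amine, a carboxylic acid or a longer chain like propyl, could show which holds. Among the compounds shown here, it also stays open whether the same exchange would have a similar effect on a different core, as this single pair is the only evidence for it.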